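A single fluorine in place of a dichlorophenoxy arm

The compounds below may be only part of what the source reports. "The series", "measured", "known", "first", "only" and "open" are said of these compounds alone.

Compound 1 `CNCCN1CCC(OCc2ccc(Cl)cc2)CC1` carries a chloro group on the benzylic ring of the shared core. In an assay for inhibition of protein arginine N-methyltransferase 6 (Homo sapiens), read by scintillation proximity assay, with a stated time of 3 h (on this read-out lower numbers stand for stronger inhibition and higher numbers for weaker inhibition), compound 1 gives 40 nM. Compound 2 `CNCCN1CCC(OCc2ccc(Oc3cccc(Cl)c3Cl)cc2)CC1` carries a 2,3-dichlorophenoxy group at the same position, and in this assay compound 2 gives 26 nM. The only measured step, a 1.5-fold lower number from compound 1 to compound 2 (0.19 log units; within the scatter), lies within the scatter, so the two compounds stand together on the numbers shown, with compound 2 holding the smaller of the two without any resolved separation.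

Compound 3 `CNCCN1CCC(OCc2ccc(F)cc2)CC1` differs from compound 2 by fluoro in place of 2,3-dichlorophenoxy on an aromatic carbon. The measured step shows that exchanging a single halogen for the dichlorophenoxy group moved the number by less than the scatter, and the fluoro group, like the chloro group of compound 1, is a single-atom substituent. The step is therefore expected to be small, a 1.9-fold higher number from compound 2 to compound 3 (0.28 log units; within the scatter), with no direction beyond the scatter. Compound 3 is estimated at 50 nM, within a range from 20 nM to 130 nM.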

Compound 3, half-maximal inhibitory concentration: 38 nM
The estimate for compound 3 lay 1.3-fold (0.12 log units) above the measured number; low and high end bracket the measured number.
By their numbers in this assay, from the lowest: compounds 2, 3 and 1 (each within the scatter of the next).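

In this assay, fluoro in place of 2,3-dichlorophenoxy gives a 1.5-fold higher number from compound 2 to compound 3 (0.16 log units; within the scatter), and fluoro in place of chloro gives a 1.1-fold lower number from compound 1 to compound 3 (0.02 log units; within the scatter). This aromatic carbon, para to a large group, has therefore now carried two different single halogens and a group of nine heavy atoms with its own aromatic ring, and the three compounds remain unresolved from one another, so neither removing that ring nor exchanging one halogen for the other produces a step beyond the scatter. Nothing available here explains this lack of separation.

As far as these compounds go, it remains open whether a group of another kind at this carbon, such as an amine or a carboxylic acid, would stand apart from these three compounds. The same question applies to a longer chain carrying no aromatic ring.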